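A Phenyl for a Cyclopentyl on the Sulfonamide

The compounds below may be only part of what the source reports. "The series", "measured", "known", "first", "only" and "open" are said of these compounds alone.

Among the compounds with values here, compound 1 `CC[C@@H]1C(=O)N(C)c2cnc(Nc3ccc(S(=O)(=O)NC4CCCC4)cc3)nc2N1C1CCCC1` is one of two compounds measured in a functional assay on NCI-H1975 cells (Homo sapiens) for antiproliferative activity, read by CCK-8 assay, with a stated time of 72 h; on this read-out lower numbers stand for stronger inhibition of growth and higher numbers for weaker inhibition of growth; in this assay compound 1 gives 1710 nM. That is the higher of the two numbers, but the other compound, compound 2 `CCNC(=O)c1ccc2c(ccn2-c2ncc3c(n2)N(C2CCCC2)[C@H](CC)C(=O)N3C)c1`, gives 882 nM in this assay, and the gap between the two lies within the scatter, so they cannot be told apart on these data.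

Compound 3 `CC[C@@H]1C(=O)N(C)c2cnc(Nc3ccc(S(=O)(=O)Nc4ccccc4)cc3)nc2N1C1CCCC1` has not yet been measured. It differs from compound 1 in one place: phenyl in place of cyclopentyl on a sulfonamide nitrogen. Within the data shown here, no pair of measured compounds shows what such a swap does here, so there is nothing in the data to say which way this assay should move. The expected step of a 1.1-fold lower number from compound 1 to compound 3 (0.06 log units; within the scatter) is therefore one that stays within the scatter, with a wide range to reflect the uncertainty. Compound 3 is estimated at 1500 nM in this assay, with a likely range from 450 nM to 5000 nM.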

Compound 3, concentration for 50% growth inhibition: 6000 nM
For compound 3 the middle estimate is 4.0-fold (0.60 log units) below the measured one; measured number above the stated range.
By their numbers in this assay, from the lowest: compounds 2 and 1 (each within the scatter of the next); then compound 3.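

In this assay the swap of cyclopentyl for phenyl on the sulfonamide nitrogen gives a 3.5-fold higher number from compound 1 to compound 3 (0.55 log units; beyond the scatter) and so shows that the group on this nitrogen does affect growth inhibition. Within this one pair, the six-membered aromatic ring does not serve as an equal replacement for the five-membered non-aromatic ring. Nothing available explains why the number rises.

This single step cannot separate the effect of ring size from that of aromatic character, since the two change together here. As far as these compounds go, it also remains open whether a cyclohexyl ring or a short chain such as ethyl on this nitrogen would give a number closer to compound 1 or to compound 3, and whether a carboxylic acid or an amine on the phenyl ring would change the result for compound 3.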